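Triazolylmethyl ethers on the aromatic oxygen: compound 4

This account rests on a few compounds, and the source may have more. Where it says the series, first, only, none or still open, it means among the compounds named here.

Compound 1 `CCC(C)(C)Cc1c[nH]c(CCc2ccc(-c3ccccc3O)cc2)n1` carries a hydrogen on the oxygen on the aromatic ring; in an assay on isolated protein for binding affinity to Bombesin receptor subtype-3 (Homo sapiens) (a higher number here means a weaker inhibitor, a lower number a stronger inhibitor), compound 1 gives 31 nM. Compound 2 `CCC(C)(C)Cc1c[nH]c(CCc2ccc(-c3ccccc3OCc3nc(N)n[nH]3)cc2)n1`, with the (3-amino-1H-1,2,4-triazol-5-yl)methyl group on that oxygen, gives 27 nM in this assay, and compound 3 `CCC(C)(C)Cc1c[nH]c(CCc2ccc(-c3ccccc3OCc3nc(C(F)(F)F)n[nH]3)cc2)n1`, with the (3-(trifluoromethyl)-1H-1,2,4-triazol-5-yl)methyl group, gives 127 nM. Compound 3 stands at the highest number of the three, beyond the scatter from both others: a 4.1-fold higher number from compound 1 to compound 3 (0.61 log units; beyond the scatter), and a 4.7-fold higher number from compound 2 to compound 3 (0.67 log units; beyond the scatter). The other pair sits together: a 1.1-fold lower number from compound 1 to compound 2 (0.06 log units; within the scatter).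

Compound 4 `CCC(C)(C)Cc1c[nH]c(CCc2ccc(-c3ccccc3OCc3cnn[nH]3)cc2)n1` is the next step from compound 3: 1H-1,2,3-triazol-5-yl in place of 3-(trifluoromethyl)-1H-1,2,4-triazol-5-yl on a saturated chain carbon bound to an oxygen on an aromatic ring. Within the data shown here, the steps that bear on it are the two leading into compound 3, both modest rises in the number when the trifluoromethyl-bearing ether entered. Among the measured compounds shown here, compound 4 has no trifluoromethyl, so a modest fall back toward the numbers of compounds 1 and 2 is expected, while the change of ring isomer has no precedent in this set and widens the range. Compound 4 is thus expected to show a 3.2-fold lower number from compound 3 to compound 4 (0.50 log units; beyond the scatter). For compound 4 the estimate in this assay is 40 nM, with a range from 15 nM to 110 nM.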

Compound 4, half-maximal inhibitory concentration: 83 nM
The estimate for compound 4 lay 2.1-fold (0.32 log units) below the measured number; the range from low to high includes it.
By their numbers in this assay, from the lowest: compounds 2 and 1 (each within the scatter of the next); then compounds 4 and 3 (each within the scatter of the next).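

Dropping the trifluoromethyl while changing the ring to 1H-1,2,3-triazol-5-yl does not take the number clear of the trifluoromethyl compound in this assay: the step is a 1.5-fold lower number from compound 3 to compound 4 (0.18 log units; within the scatter), so a triazolylmethyl ether without trifluoromethyl can also sit away from the parent. Compound 4 is separated from the other two, with a 3.1-fold higher number from compound 2 to compound 4 (0.49 log units; beyond the scatter) and a 2.7-fold higher number from compound 1 to compound 4 (0.43 log units; beyond the scatter), which leaves the 3-amino-1H-1,2,4-triazol-5-yl group of compound 2 as the only one of the three triazolylmethyl ethers within the scatter of the hydrogen on the oxygen of compound 1. No measurement on hand accounts for these differences between the triazole groups.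

The steps to compound 4 change the ring arrangement and the substituent together, so the share of each stays unresolved; an unsubstituted 1H-1,2,4-triazol-5-yl or a 1H-1,2,3-triazol-5-yl carrying an amino group would separate the two. Also open, as far as these compounds go, is whether the level seen with compound 2 depends on the amino group on the triazole itself, which an aminomethyl group, a carboxylic acid or a longer chain between the oxygen and the ring would test.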